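The source may hold more compounds than are shown below. What is called first, only, known or untested is meant among the compounds shown, and "the series" means these compounds.

Measured compounds:
Compound 1, `CC(C)(C)OC(=O)N1CCC(O[C@H]2CC[C@H](Oc3cnc(S(C)(=O)=O)cn3)CC2)CC1` — 110%
Compound 2, `CS(=O)(=O)c1cnc(O[C@H]2CC[C@H](OC3CCN(C(=O)OC4CCOC4)CC3)CC2)cn1` — 105%
Compound 3, `CS(=O)(=O)c1cnc(O[C@H]2CC[C@H](OC3CCN(CC4(C(F)(F)F)CCC4)CC3)CC2)cn1` — 96%

In a functional assay on isolated protein for agonist activity at Glucose-dependent insulinotropic receptor (Homo sapiens), read by HTRF and cAMP accumulation (a lower number here means a smaller maximal response, a higher number a larger maximal response), compound 3 gives 96%, the lowest of the three numbers, though its gap to compound 2 lies within the scatter and only its gap to compound 1 lies beyond it. Compound 4, `CC(C)c1noc(CN2CCC(O[C@H]3CC[C@H](Oc4cnc(S(C)(=O)=O)cn4)CC3)CC2)n1`, is the next step from compound 3. The change is 3-isopropyl-1,2,4-oxadiazol-5-yl in place of 1-(trifluoromethyl)cyclobutyl on a saturated chain carbon bound to an amine nitrogen in a ring. All three measured steps also alter the group on the ring amine nitrogen of the shared core. The step of a number 14 percentage points lower from compound 1 to compound 3 (beyond the scatter) is the only one beyond the scatter, while a number 9 percentage points lower from compound 2 to compound 3 (within the scatter) and a number 5 percentage points lower from compound 1 to compound 2 (within the scatter) both stay within it. Changes at this part of the molecule have thus produced at most modest movement in this assay, and no step there has pushed the maximal response far from the reference. The same is expected here: the estimated step is a number 4 percentage points higher from compound 3 to compound 4 (within the scatter), within the scatter. Compound 4 is therefore expected to give 100%, with a range from 85% to 115%.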

Compound 4, largest response reached (Emax), in percent of the reference or control that the assay uses: 102%
The estimate for compound 4 lay 2 percentage points below the measured number; the measured number falls inside the stated range.
By their numbers in this assay, from the lowest: compounds 3, 4, 2 and 1 (each within the scatter of the next, the first and the last beyond it).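

In this assay, the change to 3-isopropyl-1,2,4-oxadiazol-5-yl from 1-(trifluoromethyl)cyclobutyl gives a number 6 percentage points higher from compound 3 to compound 4 (within the scatter) even though the entering group has 3 hydrogen-bond acceptors and the leaving group has none, so this position accepts an aromatic ring with 3 hetero atoms without a clear change in maximal response. Compound 4 also stays close to the two compounds with a carbonyl group on the ring amine nitrogen, with a number 3 percentage points lower from compound 2 to compound 4 (within the scatter) and a number 8 percentage points lower from compound 1 to compound 4 (within the scatter), so the (3-isopropyl-1,2,4-oxadiazol-5-yl)methyl group, unlike the group in compound 3, is not separated from tert-butoxycarbonyl. Nothing available explains this result.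

Still open, on these data alone, is what a carboxylic acid or a primary amine would do in place of the isopropyl group on the oxadiazole. A longer chain between that ring and the ring amine nitrogen also remains untested in the compounds shown here.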